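The source may hold more compounds than are shown below. What is called first, only, known or untested is meant among the compounds shown, and "the series" means these compounds.

Measured in a functional assay on MCF7 cells (Homo sapiens) for antiproliferative activity, read by MTT assay, with a stated time of 72 h; a higher number here means a weaker inhibitor, a lower number a stronger inhibitor:
- compound 1 `COc1ncc(-c2ccc3c(c2)N(c2ccc(C)cc2)C(=O)CO3)cc1NS(=O)(=O)c1ccc(F)cc1`: 15400 nM
- compound 2 `COc1ncc(-c2ccc3c(c2)N(C2CC2)C(=O)CO3)cc1NS(=O)(=O)c1ccc(F)cc1`: 35200 nM
- compound 3 `COc1ccc(N2C(=O)COc3ccc(-c4cnc(OC)c(NS(=O)(=O)c5ccc(F)cc5)c4)cc32)cc1`: 8260 nM

Compound 3 sits with compound 1 at the low end of these values, and the two cannot be told apart: a 1.9-fold lower number from compound 1 to compound 3 (0.27 log units; within the scatter). Compound 2 stands clearly away from compound 3, with a 4.3-fold lower number from compound 2 to compound 3 (0.63 log units; beyond the scatter).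

The next compound, compound 4 `COc1ncc(-c2ccc3c(c2)N(C(C)C)C(=O)CO3)cc1NS(=O)(=O)c1ccc(F)cc1`, carries isopropyl in place of 4-methoxyphenyl on an amide-type nitrogen in a ring. Its value in this assay is not yet known.

Among the compounds with values here, two measured steps bear on this change, and both are modest. Replacing the 4-methylphenyl of compound 1 with cyclopropyl gave a 2.3-fold higher number from compound 1 to compound 2 (0.36 log units; beyond the scatter), and the exchange between cyclopropyl and 4-methoxyphenyl gave a 4.3-fold lower number from compound 2 to compound 3 (0.63 log units; beyond the scatter). Among these three compounds, none goes against the two aryl compounds having lower numbers than the cyclopropyl compound. Isopropyl itself has not been measured, so cyclopropyl in compound 2 serves as the nearest guide, at 35200 nM. Within the data shown here, a modest step towards a higher number is therefore expected, close in size to the one separating compound 2 and compound 3.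

The expected change is a 3.6-fold higher number from compound 3 to compound 4 (0.56 log units; beyond the scatter). For compound 4 the estimated value is 30000 nM, with an expected range from 14000 nM to 60000 nM.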

Compound 4, half-maximal inhibitory concentration: 17000 nM
Compound 4: middle estimate off by 1.8-fold (0.25 log units), on the high side; low and high end bracket the measured number.
By their numbers in this assay, from the lowest: compounds 3, 1 and 4 (each within the scatter of the next, the first and the last beyond it); then compound 2.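

In this assay, isopropyl on the amide-type nitrogen, a group with no ring, cannot be told apart from the 4-methylphenyl group (a 1.1-fold higher number from compound 1 to compound 4 (0.04 log units; within the scatter)), so among these compounds an aromatic ring at this position is not needed to reach the values of compound 1. Isopropyl still separates from 4-methoxyphenyl (a 2.1-fold higher number from compound 3 to compound 4 (0.31 log units; beyond the scatter)) and also from cyclopropyl (a 2.1-fold lower number from compound 2 to compound 4 (0.32 log units; beyond the scatter)), so the earlier gap between cyclopropyl and the two aryl compounds cannot be read as a simple split between aryl and non-aryl groups, with compound 4 the one that goes against such a split. No measurement offered here accounts for any of these steps.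

The compounds shown leave open how far this position tolerates other kinds of group, such as a longer chain like n-butyl, a benzyl group, or a chain ending in an amine or a carboxylic acid. They also leave open whether the separation of 4-methoxyphenyl from isopropyl would hold on a core with a different sulfonamide aryl group.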